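Swapping a sulfur side chain for methoxy

This account rests on a few compounds, and the source may have more. Where it says the series, first, only, none or still open, it means among the compounds named here.

- compound 1 `Cc1c(C)c2c(c(C)c1N)CC(C)(CSc1ccccc1)O2` gives 24.7 mg/kg
- compound 2 `Cc1c(C)c2c(c(C)c1N)CC(C)(CSCCC(=O)O)O2` gives 43 mg/kg

In a functional assay on the whole organism with Mus musculus as the target (on this read-out higher numbers stand for an effect only at larger amounts of compound and lower numbers for an effect already at smaller amounts), compound 2 lies within the usual scatter of compound 1. Compound 3 `COCC1(C)Cc2c(C)c(N)c(C)c(C)c2O1` carries methoxy in place of (2-carboxyethyl)sulfanyl on a saturated chain carbon bound to a saturated ring carbon. Among the measured compounds shown here, the only measured step, a 1.7-fold higher number from compound 1 to compound 2 (0.24 log units; within the scatter), replaced a group on the sulfur and stayed within the scatter. For the measured compounds named here, no measured compound carries methoxy, so this single step is a weak guide, and no change beyond the scatter is expected in this assay. The estimated step is a 1.4-fold lower number from compound 2 to compound 3 (0.16 log units; within the scatter). The estimate for compound 3 is 30 mg/kg, with an expected range from 12 mg/kg to 75 mg/kg.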

Compound 3, dose for 50% inhibition: 20.1 mg/kg
Compound 3: the middle estimate sits 1.5-fold (0.17 log units) above what was measured, within the range that was stated.
By their numbers in this assay, from the lowest: compounds 3, 1 and 2 (each within the scatter of the next, the first and the last beyond it).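

In this assay, methoxy in place of (2-carboxyethyl)sulfanyl gives a 2.1-fold lower number from compound 2 to compound 3 (0.33 log units; beyond the scatter) and is the only step among these compounds to pass the scatter, though modestly. Methoxy in place of phenylsulfanyl gives a 1.2-fold lower number from compound 1 to compound 3 (0.09 log units; within the scatter) and so shows that a sulfur on this saturated chain carbon is not needed for a number at this level. Nothing available explains why the two side chains differ from methoxy by different amounts. As far as these compounds go, it remains open how a hydroxyl, an amine or a longer ether such as ethoxy would read at this place.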